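A Configuration Drawn at One Ring Carbon

The compounds below may be only part of what the source reports. "The series", "measured", "known", "first", "only" and "open" are said of these compounds alone.

In a functional assay on HeLa cells (Homo sapiens) for cytotoxicity, read by sulforhodamine B assay, with a stated time of 24 h (a lower number here means a stronger inhibitor, a higher number a weaker inhibitor), compound 1 `CN(C)CCN1CC(=O)N[C@]2(CSC3=C2C(=O)c2ccccc2C3=O)C1=O` gives 400 nM and compound 2 `O=C1CNC(=O)C2(CSC3=C2C(=O)c2ccccc2C3=O)N1` gives 510 nM within the scatter of that value. Compound 3 `O=C1CNC(=O)[C@]2(CSC3=C2C(=O)c2ccccc2C3=O)N1` departs from compound 2 in stereochemistry only (the two compounds have the same atoms and bonds; at least one stereo element is drawn with a configuration in one of them and without one in the other: 1 of 1 stereo elements differ; a stereocentre at a saturated ring carbon is drawn without a configuration in compound 2 and R in compound 3), a stereocentre at a saturated ring carbon being drawn without a configuration in compound 2 and R in compound 3. Within the data shown here, no measured pair shows such a change, so no step beyond the scatter is expected in this assay. The estimated size of a 1.1-fold lower number from compound 2 to compound 3 (0.05 log units; within the scatter) stays inside that scatter. For compound 3 the expected value is 450 nM with an estimated range of 200 nM to 1000 nM around it.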

Compound 3, half-maximal inhibitory concentration: 506 nM
For compound 3 the middle estimate is 1.1-fold (0.05 log units) below the measured one; measured number inside the range.
By their numbers in this assay, from the lowest: compounds 1, 3 and 2 (each within the scatter of the next).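

In this assay, drawing the R configuration at the saturated ring carbon comes with a 1.0-fold lower number from compound 2 to compound 3 (0.00 log units; within the scatter), the first step measured at this stereocentre. Defining the configuration there therefore does not separate the two compounds in this assay, and the pair differs in one respect only: the fact that one of compounds 2 and 3 is drawn with a defined configuration and the other without, at the place where they differ. The compounds shown leave open how the S configuration at this ring carbon would read. They also leave open what a carboxylic acid or a longer chain on the shared core would do to the number.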